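The compounds below may be only part of what the source reports. "The series", "measured", "known", "first", "only" and "open" are said of these compounds alone.

Measured compounds:
Compound 1, `COCC[C@H]1C[C@@H]1c1cncc(N2CCCNCC2)c1`, gives 0.3 nM.
Compound 3, `COCC[C@H]1C[C@@H]1c1cncc(N2CCCN(C)CC2)c1`, gives 18.1 nM.
Compound 2, `CN1CCCN(c2cncc(-c3cc(CCO)no3)c2)CC1`, gives 46.3 nM.

These three compounds were tested in an assay on a protein complex for displacement of a labelled ligand from Neuronal acetylcholine receptor; alpha2/beta2 (Rattus norvegicus), read by scintillation counting; a lower number here means a stronger inhibitor, a higher number a weaker inhibitor. Compound 2 stands highest of the three, and its nearest neighbour is compound 3. How the core of compound 2 differs from the core of compound 3 is not broken down here. Compounds 3 and 1 share a core and differ in one place: hydrogen in place of methyl on an amine nitrogen in a ring. That change is measured: a 60-fold lower number from compound 3 to compound 1 (1.78 log units; beyond the scatter).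

Compound 4, `OCCc1cc(-c2cncc(N3CCCNCC3)c2)on1`, has not yet been measured in this assay. It differs from compound 2 in the same way: hydrogen in place of methyl on an amine nitrogen in a ring. The place of the change reads the same in both pairs, so the change is the same, made here on the core of compound 2. Taking the measured step as a guide, the step from compound 2 to compound 4 is expected to be about a 51-fold lower number from compound 2 to compound 4 (1.71 log units; beyond the scatter), because the matching step on the other core was a 60-fold lower number from compound 3 to compound 1 (1.78 log units; beyond the scatter). The estimated value for compound 4 in this assay is therefore 0.9 nM, expected to fall between 0.25 nM and 4 nM.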

Compound 4, inhibition constant: 0.8 nM
Beside the measured number, compound 4's estimate is 1.1-fold (0.05 log units) above it; the measured number falls inside the stated range.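

In this assay, taking the methyl off the amine nitrogen gives a 58-fold lower number from compound 2 to compound 4 (1.76 log units; beyond the scatter). The change therefore carried over from one core to the other with its size unchanged: the same change on two cores in this assay, a 60-fold lower number (1.78 log units; beyond the scatter) from compound 3 to compound 1 and a 58-fold lower number (1.76 log units; beyond the scatter) from compound 2 to compound 4, 1.0-fold (0.02 log units) apart, within the scatter of two such steps

This agreement rests on just two pairs of compounds, so it does not show that the step would keep its size on any further core, and it does not explain why the step is so large.

The compounds shown leave open what a group larger than methyl, such as ethyl or acetyl, would do on that nitrogen. They also leave open whether the step would hold on a core in which an amine takes the place of the hydroxyl group of compound 4.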